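Chain extension on the ether oxygen of the shared core

The source may report more compounds than this note shows. Statements on the series, on what has been measured and on what is new or still open speak of the compounds shown alone.

Measured compounds in a functional assay on PC-3 cells (Homo sapiens) for antiproliferative activity, read by WST assay, with a stated time of 3 days; on this read-out higher numbers stand for weaker inhibition and lower numbers for stronger inhibition:
compound 1 `CCOc1c(-c2cc(OC)c(OC)c(OC)c2)oc2ccccc2c1=O`: 900 nM
compound 2 `CCCCOc1c(-c2cc(OC)c(OC)c(OC)c2)oc2ccccc2c1=O`: 12800 nM
compound 3 `CCCCN(CCCC)CCCOc1c(-c2cc(OC)c(OC)c(OC)c2)oc2ccccc2c1=O`: 7100 nM

Compound 1 gives the lowest number of the three in this assay. Its two neighbours both lie beyond the scatter from it: the step of a 14-fold higher number from compound 1 to compound 2 (1.15 log units; beyond the scatter) is the larger of the two, and the step of a 7.9-fold higher number from compound 1 to compound 3 (0.90 log units; beyond the scatter) is smaller but still clear. Between compound 2 and compound 3 the step of a 1.8-fold lower number from compound 2 to compound 3 (0.26 log units; within the scatter) lies within the scatter, so these two cannot be ordered.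

Compound 4 `CCCCCN(CCCCC)CCCOc1c(-c2cc(OC)c(OC)c(OC)c2)oc2ccccc2c1=O` is not yet measured. Compared with compound 1 it carries (dipentylamino)methyl in place of hydrogen on a saturated chain carbon, two bonds along the chain from an oxygen on an aromatic ring. Among the measured compounds shown here, the closest measured step is the one from compound 1 to compound 3, where a (dibutylamino)methyl group entered at the same place and the number rose by a 7.9-fold higher number from compound 1 to compound 3 (0.90 log units; beyond the scatter). For the measured compounds named here, compound 4 differs from compound 3 only in the length of the two chains on the nitrogen, and no measured pair separates such a change. The expectation is therefore a step of about the size of a 7.9-fold higher number from compound 1 to compound 3 (0.90 log units; beyond the scatter), upward, so that compound 4 is estimated at 8000 nM (range 3000 nM to 25000 nM), a step of an 8.9-fold higher number from compound 1 to compound 4 (0.95 log units; beyond the scatter).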

Compound 4, half-maximal inhibitory concentration: 5800 nM
Compound 4: middle estimate off by 1.4-fold (0.14 log units), on the high side, within the range that was stated.
By their numbers in this assay, from the lowest: compound 1; then compounds 4, 3 and 2 (each within the scatter of the next, the first and the last beyond it).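

In this assay, among the compounds shown here, the swap of dipentylamino for dibutylamino, three bonds along the chain from an oxygen on an aromatic ring, gives no readable difference (a 1.2-fold lower number from compound 3 to compound 4 (0.09 log units; within the scatter)), and this is the first pair to separate a change in the length of the two chains on the nitrogen. The entry of (dipentylamino)methyl two bonds along the chain still leaves a clear gap to the shorter chain (a 6.4-fold higher number from compound 1 to compound 4 (0.81 log units; beyond the scatter)), so compound 1 remains the strongest of the four, and the second amine-bearing chain gives the same picture as the first. Against the plain chain, dipentylamino in place of methyl gives a modest step beyond the scatter (a 2.2-fold lower number from compound 2 to compound 4 (0.34 log units; beyond the scatter)), while dibutylamino in place of methyl stays within it (a 1.8-fold lower number from compound 2 to compound 3 (0.26 log units; within the scatter)), so the two amines do not read alike against compound 2 even though they cannot be told apart from each other.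

The compounds shown leave open whether a smaller amine such as dimethylamino, or a hydroxyl at the end of the same chain, would bring the number back towards that of compound 1 (900 nM). No measurement at hand accounts for the size of any of these steps.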